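The source may hold more compounds than are shown below. What is called first, only, known or untested is meant among the compounds shown, and "the series" means these compounds.

Compound 1 `c1ccc(OCc2nc3c(OCCCN4CCCCC4)cccc3n2CCCC2CCN(CCCN3CCCCC3)CC2)cc1` gives 0.106 nM in an in vitro assay on AV12 cells for binding affinity to Neuropeptide Y receptor type 1 (Homo sapiens); a higher number here means a weaker inhibitor, a lower number a stronger inhibitor. Compound 2 `CC(C)CCN1CCC(CCCn2c(COc3ccccc3)nc3c(OCCCN4CCCCC4)cccc32)CC1` gives 0.29 nM in this assay.

Going by the values given here, compound 2 holds the higher of the two numbers, and the single measured step, a 2.7-fold higher number from compound 1 to compound 2 (0.44 log units; beyond the scatter), is the only guide available. Compound 3 `C(=C\c1ccccc1)\CN1CCC(CCCn2c(COc3ccccc3)nc3c(OCCCN4CCCCC4)cccc32)CC1` alters compound 2 on the same saturated chain: 2-phenylethenyl in place of isobutyl on a saturated chain carbon bound to an amine nitrogen in a ring. The measured step concerned a different group and position on that chain and was modest, so a small step in this assay is expected, possibly none beyond the scatter, a 1.2-fold higher number from compound 2 to compound 3 (0.08 log units; within the scatter). Compound 3 is therefore estimated at 0.35 nM in this assay, within 0.1 nM to 1.2 nM.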

Compound 3, inhibition constant: 0.183 nM
Compound 3: the middle estimate sits 1.9-fold (0.28 log units) above what was measured; measured number inside the range.
By their numbers in this assay, from the lowest: compounds 1, 3 and 2 (each within the scatter of the next, the first and the last beyond it).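

In this assay, 2-phenylethenyl in place of isobutyl on a saturated chain carbon bound to an amine nitrogen in a ring gives a 1.6-fold lower number from compound 2 to compound 3 (0.20 log units; within the scatter) and so shows that this position can carry an aromatic ring with no step beyond the scatter. Replacing 2-(piperidin-1-yl)ethyl with 2-phenylethenyl gives a 1.7-fold higher number from compound 1 to compound 3 (0.24 log units; within the scatter) and so shows that a group without that piperidine ring can also stay within the scatter of compound 1. No outside measurement offers an explanation for these numbers. From the compounds shown here alone, what an amine or a carboxylic acid on the phenyl ring of 2-phenylethenyl, or a longer chain in its place, would give in this assay remains open.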